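The source may report more compounds than this note shows. Statements on the series, on what has been measured and on what is new or still open speak of the compounds shown alone.

Among the measured compounds shown here, compound 2 `COc1ccccc1C(c1c(-c2ccccc2)c[n+]([O-])c2c(C)noc12)c1c(-c2ccccc2)c[n+]([O-])c2c(C)noc12` gives the higher of the two numbers measured so far: in a functional assay on HeLa cells (Homo sapiens) for cytotoxicity, read by MTT assay, with a stated time of 48 h (a lower number here means a stronger inhibitor, a higher number a weaker inhibitor), compound 2 gives 65.5 ug/mL, whereas compound 1 `Cc1noc2c(C(c3ccccc3)c3c(-c4ccccc4)c[n+]([O-])c4c(C)noc34)c(-c3ccccc3)c[n+]([O-])c12` gives 28.6 ug/mL. For the measured compounds named here, the only measured step, a 2.3-fold higher number from compound 1 to compound 2 (0.36 log units; beyond the scatter), came with the arrival of a methoxy group. Compound 3 `Cc1noc2c(C(c3ccccc3Cl)c3c(-c4ccccc4)c[n+]([O-])c4c(C)noc34)c(-c3ccccc3)c[n+]([O-])c12` differs from compound 2 by chloro in place of methoxy on an aromatic carbon. That single step is all that bears on this change; it removes the group whose arrival raised the number, so a modest fall back toward compound 1, or nothing beyond the scatter, is expected. Compound 3 is estimated at 42 ug/mL, within 22 ug/mL to 80 ug/mL. That estimate means an expected step of a 1.6-fold lower number from compound 2 to compound 3 (0.19 log units; within the scatter).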

Compound 3, half-maximal inhibitory concentration: 79 ug/mL
For compound 3 the middle estimate is 1.9-fold (0.27 log units) below the measured one, within the range that was stated.
By their numbers in this assay, from the lowest: compound 1; then compounds 2 and 3 (each within the scatter of the next).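

In this assay, chloro in place of methoxy gives a 1.2-fold higher number from compound 2 to compound 3 (0.08 log units; within the scatter) so these two groups cannot be told apart at this position. Chloro in place of hydrogen gives a 2.8-fold higher number from compound 1 to compound 3 (0.44 log units; beyond the scatter) so the higher number seen with methoxy is now matched by a second, different group on this aromatic carbon, ortho to a large group. Nothing measured here explains why these two groups give this result. Still open, on these data alone, is whether an amine or a carboxylic acid at this position would give a number closer to that of compound 1, or whether a group as small as fluoro would also differ from hydrogen.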